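The source may report more compounds than this note shows. Statements on the series, on what has been measured and on what is new or still open speak of the compounds shown alone.

Compound 1 (`CCC(=O)Nc1cc(C(=O)Nc2ccc(OC)cc2)ccc1OC(C)C`) was tested in a toxicity assay on Huh-7.5 cells (Homo sapiens) for inhibition, read by MTT assay, with a stated time of 96 h (a lower number here means that less compound is tolerated, a higher number that more compound is tolerated), where compound 1 gives 113000 nM. That is the highest of the three numbers in hand, and both gaps lie beyond the usual scatter: compound 3 (`CCC(=O)Nc1cc(C(=O)Nc2ccc(CN3CCN(C)CC3)c(C(F)(F)F)c2)ccc1OC`) gives 35300 nM, and compound 2 (`CC(C)Oc1ccc(C(=O)Nc2ccc(CN3CCN(C)CC3)c(C(F)(F)F)c2)cc1NC(=O)C(C)Br`) gives 8700 nM. Compound 4 (`CCC(=O)Nc1cc(C(=O)Nc2ccc(OC)cc2)ccc1OC`) has not yet been measured in this assay. It keeps the core of compound 1 and carries methyl in place of isopropyl on an oxygen on an aromatic ring. Going by the values given here, compound 2 and compound 3 each differ from compound 1 in more than this group, so no measured step isolates the change. Among the compounds with values here, with only this one group exchanged, the expectation is of no step beyond the scatter, and the data offer no firm direction. The estimated step is a 1.1-fold lower number from compound 1 to compound 4 (0.05 log units; within the scatter). For compound 4 the expected value is 100000 nM, with an estimated range from 45000 nM to 220000 nM.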

Compound 4, half-maximal cytotoxic concentration: 109000 nM
Compound 4: middle estimate off by 1.1-fold (0.04 log units), on the low side; the measured number falls inside the stated range.
By their numbers in this assay, from the lowest: compound 2; then compound 3; then compounds 4 and 1 (each within the scatter of the next).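

In this assay, going by these compounds alone, the exchange of isopropoxy for methoxy gives a 1.0-fold lower number from compound 1 to compound 4 (0.02 log units; within the scatter), the first step here that isolates this position. With the rest of compound 1 held in place, the number therefore shows no response to methyl in place of isopropyl on an oxygen on an aromatic ring, a reading that compound 2 and compound 3, each differing from compound 1 in more than this group, could not give. No measurement on hand offers an explanation for this result.

Going by these compounds, whether the number stays as flat with a longer chain on this oxygen, or with a chain ending in an amine or a carboxylic acid, remains open. Also open, on these data alone, is whether the same exchange reads alike on a core carrying the other groups of compound 2 or compound 3.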